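A few compounds are considered here, and "the series" means these few. Any claim that something is new, unique, unknown or untested is made for them only; others in the source may bear on it.

Measured compounds:
compound 1, `C=C[C@@](C)(CC[C@H]1C(C)=CC[C@H]2C(C)(C)CCC[C@]12C)O[C@@H]1O[C@@H](C)[C@@H](OC(C)=O)[C@H](O)[C@H]1O`, 3.1 ug/mL
compound 2, `C=C[C@@](C)(CC[C@H]1C(C)=CC[C@H]2C(C)(C)CCC[C@]12C)O[C@@H]1O[C@@H](C)[C@@H](O)[C@H](O)[C@H]1O`, 3.2 ug/mL
compound 3, `C=C[C@@](C)(CC[C@@H]1[C@@]2(C)CCCC(C)(C)[C@@H]2CC[C@@]1(C)O)O[C@H]1O[C@H](C)[C@H](O)[C@@H](O)[C@@H]1O`, > 5 ug/mL

In a functional assay on HCT-15 cells (Homo sapiens) for cytotoxicity, read by sulforhodamine B assay (on this read-out lower numbers stand for an effect already at smaller amounts and higher numbers for an effect only at larger amounts of compound), compound 1 gives 3.1 ug/mL. Compound 2, in this assay, gives 3.2 ug/mL, and the step of a 1.0-fold higher number from compound 1 to compound 2 (0.01 log units; within the scatter) shows that removing the acetyl changes little. For compound 3 this assay reports only a limit, > 5 ug/mL, so no number is known for it; this is the point (the limit of > 5 ug/mL in this assay, at which 1 of the 3 values shown sits).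

Compound 4, `C=C[C@@](C)(CC[C@@H]1[C@@]2(C)CCCC(C)(C)[C@@H]2CC[C@@]1(C)O)O[C@@H]1O[C@H](C)[C@H](O)[C@H](O)[C@H]1O`, is the next compound. Compared with compound 3 the change is the two compounds have the same atoms and bonds and differ only in configuration as drawn: 3 of 10 stereo elements differ; a stereocentre at a saturated ring carbon is drawn R in compound 3 and S in compound 4; a stereocentre at a saturated ring carbon is drawn R in compound 3 and S in compound 4; a stereocentre at a saturated ring carbon is drawn S in compound 3 and R in compound 4. Among the compounds with values here, no measured step concerns a change of configuration alone; the single measured step, from compound 1 to compound 2, is of a different kind and lies within the scatter, so it gives no guide to direction. Since compound 3 stands at a limit, compound 4 is expected to sit near that same region, with the step of a number no higher from compound 3 to compound 4 (the limit leaves the size open) estimated as small. In this assay compound 4 is expected to give about 5 ug/mL, estimated between 2 ug/mL and 12 ug/mL.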

Compound 4, concentration for half-maximal effect: > 5 ug/mL
Compound 4: no number, only a limit; the forecaster's own chance of this, stated with the estimate: 55%; the middle value sits exactly at the limit.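

Compound 3 and compound 4 are each reported in this assay only as a limit, so no step between them can be read: the limit of > 5 ug/mL in this assay, at which 2 of the 4 values shown sit.

The compounds shown leave open whether the difference in configuration between compound 3 and compound 4 alters the effect in this assay at all.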